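The compounds below may be only part of what the source reports. "The series", "measured", "known", "first", "only" and "open" are said of these compounds alone.

Measured in a functional assay on LNCaP C4-2B cells (Homo sapiens) for cytotoxicity, read by MTT assay, with a stated time of 72 h; on this read-out higher numbers stand for weaker inhibition and lower numbers for stronger inhibition:
- compound 1 `COc1cc(/C=C/C(O)=C/C(=O)/C=C/C2=C(C)CCCC2(C)C)ccc1O`: 44300 nM
- compound 2 `COc1cc(/C=C/C(O)=C/C(=O)/C=C/C2=C(C)CCCC2(C)C)cc(OC)c1OC`: 11900 nM

Compound 2 holds the lower of the two numbers, and its gap to compound 1 lies beyond the scatter. Going by the values given here, no measured pair differs in one place only, so no direct step is available. Compound 3 `COc1cc(/C=C/C(O)=C/C(=O)/C=C/C2=C(C)CCCC2(C)C)cc(OC)c1O` follows from compound 2 by hydrogen in place of methyl on an oxygen on an aromatic ring, methoxy to hydroxy. Compound 1, which also bears a hydroxy on the aromatic ring, gives 44300 nM, so a modest rise in the number is expected, of about the size of the scatter. The expected change is a 1.7-fold higher number from compound 2 to compound 3 (0.23 log units; within the scatter). For compound 3 the estimated value is 20000 nM, with an expected range of 8000 nM to 45000 nM.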

Compound 3, half-maximal inhibitory concentration: 9800 nM
Compound 3: middle estimate off by 2.0-fold (0.31 log units), on the high side, within the range that was stated.
By their numbers in this assay, from the lowest: compounds 3 and 2 (each within the scatter of the next); then compound 1.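

In this assay, hydrogen in place of methyl on an oxygen on an aromatic ring gives a 1.2-fold lower number from compound 2 to compound 3 (0.08 log units; within the scatter), so this read-out does not separate methoxy from hydroxy at this place. Methoxy in place of hydrogen on an aromatic carbon gives a 4.5-fold lower number from compound 1 to compound 3 (0.66 log units; beyond the scatter) and is the first single-place step beyond the scatter, which shows that the hydroxy of compound 3 does not by itself carry the number of compound 1. No measurement bears on the reason for either step. Open, as far as these compounds go, is how an amine or an ethoxy group would read at this place.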